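A few compounds are considered here, and "the series" means these few. Any claim that something is new, unique, unknown or untested is made for them only; others in the source may bear on it.

Of the compounds shown here, three built on one shared core have been measured in a functional assay on MCF7 cells (Homo sapiens) for cytotoxicity, read by MTT assay, with a stated time of 4 days; a higher number here means a weaker inhibitor, a lower number a stronger inhibitor. Compound 1 `C=C1C[C@]23C[C@@]1(O)CC[C@H]2c1ccc(O)c(C)c1[C@@H]3Cn1cc(-c2ccccn2)nn1` gives > 20000 nM in this assay, and that figure is a limit of the assay rather than a number. Compound 2 `C=C1C[C@]23C[C@@]1(O)CC[C@@H]2c1cccc(C)c1[C@@H]3Cn1cc(-c2ccc(Br)cc2)nn1` gives > 20000 nM in this assay, which is likewise a limit and not a number. Compound 3 `C=C1C[C@]23C[C@@]1(O)CC[C@H]2c1cc(Br)c(O)c(C)c1[C@@H]3Cn1cc(-c2ccccc2)nn1` gives > 20000 nM in this assay, again only a limit. No step between any two of these compounds can therefore be sized, and all that can be said of where compound 2 stands is that it sits at the limit of > 20000 nM in this assay, at which 3 of the 3 values shown sit, in the company of compound 1 and compound 3.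

Compound 4 `C=C1C[C@]23C[C@@]1(O)CC[C@@H]2c1cccc(C)c1[C@@H]3Cn1cc(-c2ccc(C(F)(F)F)cc2)nn1` is the compound still to be measured. It is compound 2 with a single change: trifluoromethyl in place of bromo on an aromatic carbon. The three measured compounds do not separate one group at that place from another; every reading stops at the same limit. On that basis no shift beyond the usual scatter is expected, in either direction, and the estimated step is a step that the limit leaves unreadable from compound 2 to compound 4. Compound 4 is expected to give about 30000 nM in this assay, with a likely range from 10000 nM to 100000 nM, and most probably the reading will again stop at the assay limit.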

Compound 4, half-maximal inhibitory concentration: > 20000 nM
Compound 4: no number, only a limit; the forecaster's own chance of this, stated with the estimate: 80%; the middle value is on the limit's open side.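

In this assay compound 4 gives > 20000 nM, which is a limit of the assay and not a number. Going by these compounds alone, compound 2 also stops at a limit, so no step between compound 2 and compound 4 can be read. The compounds shown leave open how trifluoromethyl and bromo compare at this place, and whether any compound on the shared core gives a measurable value.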